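The source may hold more compounds than are shown below. What is called first, only, known or untested is meant among the compounds shown, and "the series" means these compounds.

In a physicochemical assay for acid dissociation, compound 1 `C#CCC(C)OC[n+]1ccn(C)c1/C=N/O` gives 8.03 and compound 2 `Cn1cc[n+](COC(c2ccccc2)C2CCCC2)c1/C=N/O` gives 8.03, which places compound 2 level with compound 1. Compound 3 `C#CCC(OC[n+]1ccn(C)c1/C=N/O)c1ccccc1` has not yet been measured. It carries propargyl in place of cyclopentyl on a saturated chain carbon bound to an aromatic carbon and an oxygen on a saturated carbon. Among the compounds with values here, no measured step covers this change, but compound 1 also carries propargyl and reads 8.03. The expected step, a number 0.03 log units lower from compound 2 to compound 3 (within the scatter), is therefore estimated to stay within the scatter, in neither direction. For compound 3 the estimated value is 8, with an expected range from 7.75 to 8.25.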

Compound 3, acid dissociation constant: 7.99
Compound 3: middle estimate off by 0.01 log units, on the high side; measured number inside the range.
By their numbers in this assay, from the lowest: compounds 3, 1 and 2 (each within the scatter of the next).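

In this assay, propargyl in place of cyclopentyl on a saturated chain carbon bound to an aromatic carbon and an oxygen on a saturated carbon gives a number 0.04 log units lower from compound 2 to compound 3 (within the scatter), while phenyl in place of methyl on a saturated chain carbon bound to an oxygen on a saturated carbon and a saturated chain carbon gives a number 0.04 log units lower from compound 1 to compound 3 (within the scatter). Each of these two single changes thus stays within the scatter. No evidence is available that bears on this result. From the compounds shown here alone, whether an amine or a carboxylic acid at this carbon would leave the reading equally unmoved remains open.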